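This account rests on a few compounds, and the source may have more. Where it says the series, first, only, none or still open, it means among the compounds named here.

Compound 1, `CCOc1ccc(-c2cccc(C(=O)O)c2)cc1`, in an assay on COS-7 cells for inhibition of patatin-like phospholipase domain-containing protein 2 (Mus musculus); a higher number here means a weaker inhibitor, a lower number a stronger inhibitor: > 200000 nM, which is a limit of the assay.
Compound 2, `CCOc1ccc(-c2cccc(C(=O)OCC(F)(F)F)c2)cc1`, in this assay: 120000 nM.

Compound 1 stands only at a bound, (the limit of > 200000 nM in this assay, at which 1 of the 2 values shown sits), so no number is known for it. Compound 3, `CCOc1ccc(-c2cccc([N+](=O)[O-])c2)cc1`, differs from compound 1 by nitro in place of carboxy on an aromatic carbon. For the measured compounds named here, the single measured step, an at least 1.6-fold lower number from compound 1 to compound 2 (0.22 log units; that floor lies within the scatter), also removes the carboxy hydrogen and barely moves the number. Compound 3 is therefore expected to stay weak, with a step of an at least 1.3-fold lower number from compound 1 to compound 3 (0.12 log units; that floor lies within the scatter) that may not exceed the scatter. For compound 3 the estimated value is 150000 nM, in a range from 50000 nM to 400000 nM.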

Compound 3, half-maximal inhibitory concentration: > 200000 nM
Compound 3: a limit, no number; the forecaster's own chance of this, stated with the estimate: 50%; at least 1.3-fold (0.12 log units) between middle value and limit.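

Compound 1 and compound 3 both stand only at a limit in this assay, so no step can be read between them: the limit of > 200000 nM in this assay, at which 2 of the 3 values shown sit.

From the compounds shown here alone, whether nitro in place of carboxy changes the number at all stays open.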